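Sulfur for oxygen at the aryl ether of compound 1

The compounds below may be only part of what the source reports. "The series", "measured", "known", "first", "only" and "open" are said of these compounds alone.

Compound 1 `Nc1cc(N)c2nc(-c3ccccc3)c(Oc3ccc(Cl)c(Cl)c3)nc2c1` is the parent here. In a functional assay on OVCAR-8 cells (Homo sapiens) for inhibition, read by sulforhodamine B assay, with a stated time of 48 h (a lower number here means that less compound is tolerated, a higher number that more compound is tolerated), compound 1 shows only a limit, < 100000 nM, not a number. Compound 2 `CCOC(=O)[C@H](CCC(=O)O)NC(=O)c1ccc(CNc2nc3cc(N)cc(N)c3nc2-c2ccccc2)cc1` likewise gives only a limit in this assay, < 100000 nM. Compound 3 `CCOC(=O)[C@H](CCC(=O)O)NC(=O)c1ccc(Sc2nc3cc(N)cc(N)c3nc2-c2ccccc2)cc1` also sits at a limit in this assay, < 100000 nM. For the measured compounds named here, no compound yet has a measured number, since (the limit of < 100000 nM in this assay, at which 3 of the 3 values shown sit). Compound 4 `Nc1cc(N)c2nc(-c3ccccc3)c(Sc3ccc(Cl)c(Cl)c3)nc2c1` carries (3,4-dichlorophenyl)sulfanyl in place of 3,4-dichlorophenoxy on an aromatic carbon. Among the measured compounds the pair compound 2 and compound 3 shows only that both remain at a limit. The step from compound 1 to compound 4 is expected to be a step that the limit leaves unreadable from compound 1 to compound 4, nothing beyond the scatter. Compound 4 is estimated at 25000 nM, between 4000 nM and 95000 nM, with a fair chance that only a limit is reported again.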

Compound 4, concentration lethal to 50% of the cells: < 100000 nM
Compound 4: only a limit was reported; the forecaster's own chance of this, stated with the estimate: 65%; the middle value does not contradict the limit.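

Compound 1 and compound 4 both give only a limit, so no step can be read between them: the limit of < 100000 nM in this assay, at which 4 of the 4 values shown sit.

Whether (3,4-dichlorophenyl)sulfanyl in place of 3,4-dichlorophenoxy shifts the lethal concentration at all remains open, as does any ranking of the compounds shown.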